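A few compounds are considered here, and "the series" means these few. Any claim that something is new, unique, unknown or untested is made for them only; others in the source may bear on it.

Measured in a functional assay on COLO 205 cells (Homo sapiens) for inhibition, read by sulforhodamine B assay, with a stated time of 48 h, tested at 50 uM; a higher number here means more inhibition of growth at the concentration tested, a lower number less inhibition of growth:
compound 3 `COc1ccccc1/C=C/C(=O)/C=C/c1ccc(OCc2cn(CCCCOc3cc(=O)oc4ccccc34)nn2)c(OC)c1` gives 47%
compound 1 `COc1cc(/C=C/C(=O)/C=C/c2ccccc2)ccc1OCc1cn(CCCOc2cc(=O)oc3ccccc23)nn1` gives 43%
compound 2 `COc1ccc(/C=C/C(=O)/C=C/c2ccc(OCc3cn(CCCCCOc4cc(=O)oc5ccccc45)nn3)c(OC)c2)cc1` gives 30%

Compound 3 holds the highest of the three numbers in this assay. Compound 1 lies nearest, its reading within the scatter of that of compound 3, so the two cannot be told apart on these data. Compound 2 lies furthest, beyond the scatter below compound 3. For the measured compounds named here, no pair among the three measured compounds differs in a single place, so there is no measured step that can be carried over to a new compound.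

Compound 4 `COc1cc(/C=C/C(=O)/C=C/c2cccs2)ccc1OCc1cn(CCCCOc2cc(=O)oc3ccccc23)nn1` is the compound still to be measured in this assay. Against compound 3 it differs in one place: thiophen-2-yl in place of 2-methoxyphenyl on a double-bonded chain carbon bound to a double-bonded chain carbon. Going by the values given here, none of the measured compounds carries a thiophen-2-yl ring at that position, so the data give no direct guide to the size or sign of the change.

The step in this assay from compound 3 to compound 4 is expected to be small, most likely a slight decrease that does not clearly exceed the scatter: a number 7 percentage points lower from compound 3 to compound 4 (within the scatter). For compound 4 the estimate in this assay is 40%, with a range from 24% to 56%.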

Compound 4, percent growth inhibition at one concentration: 40%
For compound 4 middle estimate and measured number coincide at the digits printed; the measured number falls inside the stated range.
By their numbers in this assay, from the lowest: compounds 2, 4, 1 and 3 (each within the scatter of the next, the first and the last beyond it).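

In this assay, for the compounds shown here, the change at this place gives a number 7 percentage points lower from compound 3 to compound 4 (within the scatter), and this is the first step that can be read across a single difference. The thiophen-2-yl ring, with 5 heavy atoms and a sulfur in a five-membered aromatic ring, cannot be told apart on this read-out from the 2-methoxyphenyl ring, with 8 heavy atoms and an oxygen, so on this one pair, replacing that ring on a double-bonded chain carbon bound to a double-bonded chain carbon leaves no effect that stands clear of the scatter. No measurement accompanies the result that would explain it.

Going by these compounds alone, the single pair leaves open how far this holds for other groups at the same place, for instance a pyridin-3-yl ring, a dimethylamino group or a carboxylic acid carried on the ring, any of which could move the reading clear of the scatter. The length of the chain on the other side of the core also stays unresolved, as compound 1 and compound 2 each differ from compound 3 in more than one place, so a longer or shorter chain has no clean comparison here.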